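Two Anilide Swaps on a Catechol Diaryl Ether Scaffold

The compounds below may be only part of what the source reports. "The series", "measured", "known", "first", "only" and "open" are said of these compounds alone.

The series was tested in a functional assay on HeLa cells (Homo sapiens) for inhibition, read by CCK-8 assay, with a stated time of 48 h; a lower number here means a stronger inhibitor, a higher number a weaker inhibitor. Compound 1 `CC(C)c1ccc(Oc2ccc(O)c(O)c2)c(-c2ccsc2S(=O)(=O)NCCNC(=S)Nc2ccc([N+](=O)[O-])cc2)c1` is reported only as a limit of the assay, > 20000 nM, rather than as a number. Compound 3 `CC(C)c1ccc(Oc2ccc(O)c(O)c2)c(-c2ccsc2S(=O)(=O)NCCNC(=O)Nc2cc(Cl)cc(Cl)c2)c1` is likewise reported only as a limit, > 50000 nM, and not as a number. Compound 3 differs from compound 1 by a group of 11 heavy atoms (7 carbon, 1 nitrogen, 1 oxygen, 2 chlorine; one six-membered aromatic ring of carbon only) in place of a group of 12 heavy atoms (7 carbon, 2 nitrogen, 2 oxygen, 1 sulfur; one six-membered aromatic ring of carbon only), on an amine nitrogen. For the measured compounds named here, because both values sit at limits, the limit of > 20000 nM in this assay, at which 1 of the 3 values shown sits, and (the limit of > 50000 nM in this assay, at which 1 of the 3 values shown sits), the step that the two limits leave unreadable from compound 1 to compound 3 cannot be read in size or direction; it shows only that neither compound reached a measurable number.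

Going by the values given here, compound 2 `Cc1ccc(-c2ccsc2S(=O)(=O)NCCNC(=S)Nc2ccc([N+](=O)[O-])cc2)c(Oc2ccc(O)c(O)c2)c1` is the one member of the set with a number: in this assay compound 2 gives 6800 nM. The difference between the core of compound 2 and the core of compound 1 is not broken down here.

Compound 4 `Cc1ccc(-c2ccsc2S(=O)(=O)NCCNC(=O)Nc2cc(Cl)cc(Cl)c2)c(Oc2ccc(O)c(O)c2)c1` has not yet been measured. It differs from compound 2 by a group of 11 heavy atoms (7 carbon, 1 nitrogen, 1 oxygen, 2 chlorine; one six-membered aromatic ring of carbon only) in place of a group of 12 heavy atoms (7 carbon, 2 nitrogen, 2 oxygen, 1 sulfur; one six-membered aromatic ring of carbon only), on an amine nitrogen, the same change that leads from compound 1 to compound 3, at a place described in the same words. Since that earlier step is unreadable, it gives no direction for compound 4. Among the compounds with values here, the expectation therefore rests mainly on the value of compound 2, 6800 nM, as the only number in hand. Compound 4 is expected to give 20000 nM in this assay, with a range estimated from 5000 nM to 60000 nM. The estimated step this implies is a 2.9-fold higher number from compound 2 to compound 4 (0.47 log units; beyond the scatter), and a result reported only as a limit is considered quite possible.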

Compound 4, half-maximal inhibitory concentration: 6500 nM
Estimate against measurement, compound 4: 3.1-fold (0.49 log units) above; the measured number falls inside the stated range.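

In this assay, placing the (3,5-dichlorophenyl)carbamoyl group on the amine nitrogen of the core of compound 2, where the thiourea-bearing group of the same size stood, gives a 1.0-fold lower number from compound 2 to compound 4 (0.02 log units; within the scatter), so on this core the two groups cannot be told apart. The same change on the core of compound 1 leaves a step that cannot be read, because compound 1 and compound 3 are each reported only as a limit of the assay and not as a number: the limit of > 20000 nM in this assay, at which 1 of the 4 values shown sits, and (the limit of > 50000 nM in this assay, at which 1 of the 4 values shown sits). The pair of compound 2 and compound 4 therefore shows a matched result on one core only, and it does not show that the change carries over to the core of compound 1, nor that it would behave differently there.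

The compounds shown leave open whether the core of compound 1 would give a readable step with this change at all, as neither of its two members reaches a number. They also leave open what an amine, a carboxylic acid or a longer chain would do on the same amine nitrogen, on either core.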